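Swapping the Five-Membered Ring for Pyridine on a Shared Core

This account rests on a few compounds, and the source may have more. Where it says the series, first, only, none or still open, it means among the compounds named here.

Compound 1 `Oc1ccc(-c2cc(-c3ccco3)cc(-c3ccc(O)cc3)n2)cc1`: in a functional assay on DU-145 cells (Homo sapiens) for cytotoxicity, read by CCK-8 assay (a lower number here means a stronger inhibitor, a higher number a weaker inhibitor), compound 1 gives > 50000 nM, which is a limit of the assay rather than a number.
Compound 2 `Oc1ccc(-c2cc(-c3ccoc3)cc(-c3ccc(O)cc3)n2)cc1`: in this assay compound 2 gives 3440 nM.

For the measured compounds named here, compound 2 carries the only actual number in this small set; the other value sits at a limit, namely (the limit of > 50000 nM in this assay, at which 1 of the 2 values shown sits). Compound 3 `Oc1ccc(-c2cc(-c3ccccn3)cc(-c3ccc(O)cc3)n2)cc1` has not yet been measured. It differs from compound 2 in one place: pyridin-2-yl in place of furan-3-yl on an aromatic carbon.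

Going by the values given here, only one measured step bears on this change, the exchange of one heteroaryl group for another at the same position: an at least 14-fold lower number from compound 1 to compound 2 (1.16 log units; beyond the scatter). That step was large, so a second exchange of the heteroaryl group at this position could again move the number well beyond the scatter. The data do not show in which direction a pyridin-2-yl group would push it. Compound 3 is therefore estimated at 6000 nM, with a range from 800 nM to 50000 nM. This estimate corresponds to an expected step of a 1.7-fold higher number from compound 2 to compound 3 (0.24 log units; within the scatter).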

Compound 3, half-maximal inhibitory concentration: > 50000 nM
Compound 3: only a limit was reported; the forecaster's own chance of this, stated with the estimate: 25%; middle value at least 8.3-fold (0.92 log units) from the limit.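

Putting pyridin-2-yl in place of furan-3-yl gives an at least 14-fold higher number from compound 2 to compound 3 (1.16 log units; beyond the scatter), so in this assay the number at this position has now moved strongly a second time, and this time toward weaker inhibition. Of the three aromatic rings shown here, only the furan-3-yl group of compound 2 gives an actual number, so having a single hetero atom in an aromatic ring does not by itself ensure a measurable result. Compound 1 and compound 3 cannot be ranked against each other and the step between them cannot be read, because both values are limits rather than numbers: the limit of > 50000 nM in this assay, at which 2 of the 3 values shown sit.

The compounds shown leave open whether pyridin-3-yl or pyridin-4-yl would behave like pyridin-2-yl. They also leave open whether a non-aromatic group at this position, such as an amine or a morpholine, would give a measurable number.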